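The source may hold more compounds than are shown below. What is called first, only, known or untested is meant among the compounds shown, and "the series" means these compounds.

In an ADME assay on microsomes from liver (Mus musculus) for metabolic stability, read by LC-MS, with a stated time of 40 min, tested at 0.5 uM (a lower number here means slower removal, a higher number faster removal of the compound), compound 1 (`O=C(Nc1cccc(S(=O)(=O)C2CCCC2)c1)c1cccnc1N1CCC(F)(F)CC1`) gives > 399 mL.min-1.g-1, which is a limit and not a number. Compound 2 (`CC(C)(C)NS(=O)(=O)c1cccc(NC(=O)c2cccnc2N2CCC3(CC2)CC3)c1`) gives > 399 mL.min-1.g-1, again a limit. Compound 3 (`O=C(Nc1cccc(S(=O)(=O)NC2CC2)c1)c1cccnc1N1CCC2(CC1)CC2`) gives > 399 mL.min-1.g-1, also a limit. Compound 3 therefore has no number of its own, and the series stands at the limit of > 399 mL.min-1.g-1 in this assay, at which 3 of the 3 values shown sit.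

The next structure is compound 4 (`O=C(Nc1cccc(S(=O)(=O)C2CCCC2)c1)c1cccnc1N1CCC2(CC1)CC2`). The change is cyclopentyl in place of cyclopropylamino on a sulfonyl sulfur. For the measured compounds named here, the only measured step is a step that the two limits leave unreadable from compound 2 to compound 3, with cyclopropyl in place of tert-butyl on a sulfonamide nitrogen. It concerns a different group and gives no size to carry over. The closest evidence is compound 1, which also has cyclopentyl on a sulfonyl sulfur and reads > 399 mL.min-1.g-1, a limit as well. On that reading, no step beyond the scatter is expected in this assay, and no direction can be assigned. The expected change is a step that the limit leaves unreadable from compound 3 to compound 4. The estimate for compound 4 is 420 mL.min-1.g-1, with an expected range from 250 mL.min-1.g-1 to 700 mL.min-1.g-1, and the assay will most likely report only a limit again.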

Compound 4, intrinsic clearance in microsomes: > 399 mL.min-1.g-1
Compound 4: no number, only a limit; the forecaster's own chance of this, stated with the estimate: 80%; the middle value lies beyond the limit too.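

In this assay compound 4 gives > 399 mL.min-1.g-1, which is a limit and not a number. For the compounds shown here, no step from compound 1, compound 2 or compound 3 to compound 4 can be read. The compounds shown leave open how fast each is actually removed and whether any of these changes alters that, and the series stands as follows: the limit of > 399 mL.min-1.g-1 in this assay, at which 4 of the 4 values shown sit.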